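Methoxymethyl in place of hydrogen on compound 2

The source may report more compounds than this note shows. Statements on the series, on what has been measured and on what is new or still open speak of the compounds shown alone.

Of the compounds shown here, two have been measured so far, compound 1 (`CC/C=C\C/C=C\C/C=C\CCCCCCCc1cc(=O)c2c(O)cc(OCOC)c(C)c2o1`) and compound 2 (`CC/C=C\C/C=C\C/C=C\CCCCCCCc1cc(=O)c2c(O)c(C)c(O)c(C)c2o1`). In a functional assay on MCF7 cells (Homo sapiens) for antiproliferative activity, read by MTT assay (on this read-out lower numbers stand for stronger inhibition and higher numbers for weaker inhibition), compound 1 gives 17500 nM and compound 2 gives 17500 nM, so compound 2 stands level with compound 1. Compound 3 (`CC/C=C\C/C=C\C/C=C\CCCCCCCc1cc(=O)c2c(O)c(C)c(OCOC)c(C)c2o1`) is compound 2 with a single change: methoxymethyl in place of hydrogen on an oxygen on an aromatic ring, or hydroxy to methoxymethoxy (methoxymethyl in place of hydrogen on an oxygen on an aromatic ring). Among the compounds with values here, no measured pair differs in this one place, so the size of the step cannot be read directly from the data. Within the data shown here, the only guide is compound 1, which also carries a methoxymethoxy group and gives 17500 nM. On that basis, no step beyond the scatter is expected in this assay, in either direction. The expected change, a 1.0-fold lower number from compound 2 to compound 3 (0.01 log units; within the scatter), is estimated to stay within that scatter. For compound 3 the estimated value is 17000 nM, with an expected range from 8000 nM to 35000 nM.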

Compound 3, half-maximal inhibitory concentration: > 84100 nM
Compound 3: only a limit was reported; the forecaster's own chance of this, stated with the estimate: 10%; middle value at least 4.9-fold (0.69 log units) from the limit.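

Hydroxy to methoxymethoxy on this oxygen on an aromatic ring brings an at least 4.8-fold higher number from compound 2 to compound 3 (0.68 log units; beyond the scatter) in this assay, so in this compound the free hydroxy cannot give way to methoxymethoxy without a loss of activity. Methoxymethoxy alone does not fix the level, since the group stands on both sides of the other step, methyl in place of hydrogen on an aromatic carbon, which reads an at least 4.8-fold higher number from compound 1 to compound 3 (0.68 log units; beyond the scatter) in this assay; what the group does therefore depends on the rest of the substitution on the shared core. Both steps rest on a limit and not on a number, so they give a lower bound and no exact size: the limit of > 84100 nM in this assay, at which 1 of the 3 values shown sits.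

Still open, going by these compounds, is whether the loss follows from methoxymethyl in particular or from any replacement of the hydrogen on this oxygen, which a plain methyl ether, an acetate ester or a longer alkyl ether would help to separate. On these data alone, it is equally open whether an amine in this place would stay level with compound 2, and whether the same change on the other hydroxy of the core would cost as much.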